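Working notes on a small series and one compound to be run

The compounds below may be only part of what the source reports. "The series", "measured", "known", "first", "only" and "open" are said of these compounds alone.

Measured so far:
compound 1 `C=C(CC[C@H]1C(=C)CC[C@H]2[C@@](C)(CO)CCC[C@]12C)C(=O)CO`: 19.9 ug/mL
compound 2 `C=C(C=O)CC[C@H]1C(=C)CC[C@@H]2[C@]1(C)CCC[C@@]2(C)O`: 14.8 ug/mL
compound 3 `C=C(C=O)CC[C@H]1C(=C)CC[C@@H]2[C@]1(C)CCC[C@]2(C)C(=O)O`: 14.1 ug/mL

All three were run in a functional assay on MDA-MB-231 cells (Homo sapiens) for inhibition, read by MTT assay; a higher number here means a weaker inhibitor, a lower number a stronger inhibitor. Compound 3 gives 14.1 ug/mL, the lowest of the three numbers. Compound 2 gives 14.8 ug/mL and compound 1 gives 19.9 ug/mL; both lie within the scatter of the number for compound 3, so no order among the three can be read, and none of them can be called the stronger or weaker inhibitor.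

Compound 4 `C=C1CC[C@@H]2[C@](C)(CCC[C@]2(C)C(=O)O)[C@H]1CC/C(C)=C/COC(C)=O` is not yet measured in this assay. Set against compound 3, the change is 3-acetoxy-1-methylprop-1-en-1-yl in place of 1-formylethenyl on a saturated chain carbon, two bonds along the chain from a saturated ring carbon. For the measured compounds named here, no step between measured compounds exists for this change: every measured compound carries the 1-formylethenyl group, so the three numbers say nothing about what replacing it does.

The expectation is that the step of a 2.1-fold higher number from compound 3 to compound 4 (0.33 log units; beyond the scatter) runs toward a higher number, that is a weaker inhibitor, by a margin beyond the scatter but not a large one. Compound 4 is accordingly estimated at 30 ug/mL, with a range from 12 ug/mL to 75 ug/mL; the range is kept wide because only compound 3 at 14.1 ug/mL anchors it.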

Compound 4, half-maximal inhibitory concentration: 14.8 ug/mL
The estimate for compound 4 lay 2.0-fold (0.31 log units) above the measured number; low and high end bracket the measured number.
By their numbers in this assay, from the lowest: compounds 3, 2, 4 and 1 (each within the scatter of the next).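

In this assay, the exchange of 1-formylethenyl for 3-acetoxy-1-methylprop-1-en-1-yl on a saturated chain carbon, two bonds along the chain from a saturated ring carbon, gives a 1.0-fold higher number from compound 3 to compound 4 (0.02 log units; within the scatter). For the compounds shown here, this is the first reading at this position, since the earlier compounds all carry 1-formylethenyl, and it shows that, on the core of compound 3, that group can be replaced by the larger 3-acetoxy-1-methylprop-1-en-1-yl without a change beyond the scatter. Nothing available on these compounds accounts for this result.

Going by these compounds alone, this single step shows only one replacement on one core, so whether the same exchange would read the same on the core of compound 2 remains open. Also open, going by these compounds, is what an amine or an amide in place of the acetoxy group at the end of this chain, or a longer chain carrying the same acetoxy group, would do to the number in this assay.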